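Thiosemicarbazone series: nitro substitution on the aryl hydrazone

A few compounds are considered here, and "the series" means these few. Any claim that something is new, unique, unknown or untested is made for them only; others in the source may bear on it.

Working notes. Three compounds share the core of compound 1, `CC1=CC[C@H](C(C)(C)N=C=S)CC1`, an isothiocyanate. In a functional assay on OVCAR-3 cells (Homo sapiens) for inhibition, read by sulforhodamine B assay, with a stated time of 48 h (a higher number here means a weaker inhibitor of growth, a lower number a stronger inhibitor of growth), compound 1 returns only a limit of the assay, > 100000 nM. Among the compounds with values here, compound 2, `CC1=CC[C@H](C(C)(C)NC(=S)N/N=C/c2ccc[nH]2)CC1`, carries a pyrrole hydrazone and in this assay compound 2 gives 33500 nM, the one numeric value among the three. Compound 3, `CC1=CC[C@H](C(C)(C)NC(=S)N/N=C(\C)c2ccccc2)CC1`, is the acetophenone-derived hydrazone; in this assay compound 3 likewise gives only a limit, > 100000 nM. Compound 3 therefore stands at the limit of > 100000 nM in this assay, at which 2 of the 3 values shown sit, with no number of its own to anchor a step.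

Compound 4, `CC1=CC[C@H](C(C)(C)NC(=S)N/N=C(\C)c2ccc([N+](=O)[O-])cc2)CC1`, differs from compound 3 by nitro in place of hydrogen on an aromatic carbon, para to a large group. Within the data shown here, no measured step between two compounds that differ in one place exists in this set, so the size of this change cannot be read off anything measured. With compound 3 sitting at a limit, the direction can only be estimated, and nothing in the set argues for a large movement. The step estimated here, an at least 1.4-fold lower number from compound 3 to compound 4 (0.15 log units; that floor lies within the scatter), is expected to be modest, toward stronger inhibition if anything, and likely inside the scatter. Compound 4 is expected to give about 70000 nM in this assay, between 25000 nM and 200000 nM, with a fair chance that only a limit is again reported.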

Compound 4, concentration for 50% growth inhibition: 7700 nM
Compound 4: middle estimate off by 9.1-fold (0.96 log units), on the high side, and the stated range ends above it.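

Within the data shown here, at this place on the ring, para to a large group, nitro in place of hydrogen gives the first step that can be read, in this assay: an at least 12-fold lower number from compound 3 to compound 4 (1.11 log units; beyond the scatter). The earlier compounds shown here showed no step at all, whereas this one shows that a single substitution on an aromatic carbon of the acetophenone-derived hydrazone is enough to bring the series from a limit to a numeric value, and by more than the usual scatter. The size printed is only a floor and the true step may be larger, because compound 3 has a limit rather than a number of its own: the limit of > 100000 nM in this assay, at which 2 of the 4 values shown sit.

As far as these compounds go, whether the step belongs to nitro in particular or would also follow from other groups on this same carbon stays open, and an amine, a nitrile or a carboxylic acid in place of the nitro would begin to separate these possibilities. Also open, from the compounds shown here alone, is whether nitro on the same ring carries the same size of step at other ring positions, or on a hydrazone without the methyl group of compound 4.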